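The compounds below may be only part of what the source reports. "The series", "measured", "known", "first", "only" and "open" are said of these compounds alone.

Three compounds share one core and have been measured in a functional assay on cells for positive allosteric modulation of G-protein coupled receptor 68 (Homo sapiens), read by a luciferase reporter and cAMP accumulation, with a stated time of 30 min, at pH 6.8 and pH 8.3, in the presence of a further agent that is not named here; a higher number here means a more potent compound, by a factor of ten per unit of this negative logarithm, a lower number a less potent compound:

Compound 1, `Nc1nc(NCc2ccc(F)cc2)nc(-c2ccccc2CO)n1`, gives 3.97.
Compound 2, `Nc1nc(NCc2ccc(Cl)cc2)nc(-c2ccccc2CO)n1`, gives 5.22.
Compound 3, `Cc1ccc(CNc2nc(N)nc(-c3ccccc3CO)n2)cc1`, gives 4.38.

Compound 3 stands second of these three: it lies a number 0.41 log units higher from compound 1 to compound 3 (beyond the scatter), while against compound 2 it sits lower, as shown by a number 0.84 log units lower from compound 2 to compound 3 (beyond the scatter). All three differ only in the group on the outer benzene ring, and the largest swing seen, a number 1.25 log units higher from compound 1 to compound 2 (beyond the scatter), comes from exchanging one halogen for another.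

Compound 4, `CC(C)Oc1ccc(CNc2nc(N)nc(-c3ccccc3CO)n2)cc1`, carries the change (isopropoxy in place of methyl on an aromatic carbon). For the measured compounds named here, no measured pair covers an alkoxy group, so the only guidance is that the three substituents tried so far gave clearly different numbers at the same place, with the bulkier groups of compounds 2 and 3 lying above compound 1. On that slender basis a modest rise is expected, a number 0.42 log units higher from compound 3 to compound 4 (beyond the scatter), though a fall cannot be ruled out. The estimate for compound 4 in this assay is 4.8, within a range of 4.1 to 5.5.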

Compound 4, negative logarithm of the antagonist equilibrium constant: 4.99
The estimate for compound 4 lay 0.19 log units below the measured number; the range from low to high includes it.
By their numbers in this assay, from the lowest: compound 1; then compound 3; then compounds 4 and 2 (each within the scatter of the next).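

In this assay, for the compounds shown here, this position on the outer benzene ring also takes isopropoxy, the first group that holds an oxygen and a hydrogen-bond acceptor, with a number 0.61 log units higher from compound 3 to compound 4 (beyond the scatter) and a number 1.02 log units higher from compound 1 to compound 4 (beyond the scatter). Against chloro the change gives a number 0.23 log units lower from compound 2 to compound 4 (within the scatter), so a group of 4 heavy atoms cannot be told apart from a single chlorine atom here, while fluoro and methyl, which also have a single heavy atom, gave clearly different numbers, and heavy-atom count alone therefore does not order these compounds. No measurement offered here accounts for these differences.

Going by these compounds, it remains open whether the oxygen or the carbons of isopropoxy matter more, a question that methoxy or a plain isopropyl group would address. On these data alone, how an amine or a carboxylic acid would read at this place also remains unknown.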